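The compounds below may be only part of what the source reports. "The series", "measured", "known", "first", "only" and "open" are said of these compounds alone.

Compound 1 `CC(O)(C(=O)Nc1ccc(S(=O)(=O)c2ccccc2)c(F)c1)C(F)(F)F` gives 1800 nM in a functional assay (Cavia porcellus) with sulfonylurea receptors; K-ATP channels (Homo sapiens) as the target; a lower number here means a stronger inhibitor, a higher number a weaker inhibitor.
Compound 2 `CC(O)(C(=O)Nc1ccc(S(=O)(=O)c2cccc(F)c2)cc1)C(F)(F)F` gives 3400 nM in this assay.
Compound 3 `CC(O)(C(=O)Nc1ccc(S(=O)(=O)c2ccc(C#N)cc2)cc1)C(F)(F)F` reaches only a limit of the assay, > 30000 nM, in this assay.

Compound 1 holds the lowest of the two numbers, with compound 2 within the scatter of it. Compound 3 sits at the limit of > 30000 nM in this assay, at which 1 of the 3 values shown sits. Compound 4 `Cc1cc(NC(=O)C(C)(O)C(F)(F)F)ccc1S(=O)(=O)c1ccccc1` differs from compound 1 by methyl in place of fluoro on an aromatic carbon. Among the compounds with values here, the only measured step, an at least 8.8-fold higher number from compound 2 to compound 3 (0.94 log units; beyond the scatter), concerns the ring on the sulfonyl sulfur and so does not bear on this change. Within the data shown here, no measured step covers the ring where the new group sits, so no step beyond the scatter is expected in this assay. Compound 4 is therefore estimated at 2000 nM, with a range from 700 nM to 6000 nM, which is expected to mean a 1.1-fold higher number from compound 1 to compound 4 (0.05 log units; within the scatter).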

Compound 4, half-maximal inhibitory concentration: 1600 nM
Estimate against measurement, compound 4: 1.3-fold (0.10 log units) above; the measured number falls inside the stated range.
By their numbers in this assay, from the lowest: compounds 4, 1 and 2 (each within the scatter of the next, the first and the last beyond it). At a limit, above all of these: compound 3.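

In this assay, the change at this aromatic carbon gives a 1.1-fold lower number from compound 1 to compound 4 (0.05 log units; within the scatter), so methyl in place of fluoro leaves the number within the scatter. Within the data shown here, this is the first measured step on the ring where the new group sits, as the earlier step concerned only the ring on the sulfonyl sulfur. Nothing measured here bears on why the two groups read alike.

On these data alone, whether an amine, a methoxy group or a longer chain at this position would also stay within the scatter remains open. So does whether methyl in place of fluoro would read the same with a 3-fluorophenyl or 4-cyanophenyl on the sulfonyl sulfur.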